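The source may hold more compounds than are shown below. What is called first, only, known or untested is meant among the compounds shown, and "the series" means these compounds.

Compound 1 `Cc1ccc(Oc2ccc3nc(COc4cccc(C(=O)O)c4)n(C)c3n2)cc1C` and compound 2 `Cn1c(COc2cccc(C(=O)O)c2)nc2ccc(Oc3cc(Cl)ccn3)cc21` share a core and differ in the group carried on the oxygen. In a physicochemical assay for solubility, read by HPLC, measured as thermodynamic solubility, with a stated time of 4 h, at pH 6.8 (a lower number here means a less soluble compound, a higher number a more soluble compound), compound 1 gives 16 ug/mL, and in this assay compound 2 gives 11 ug/mL; the two values lie within the usual scatter of each other, so neither can be placed above the other. Compound 3 `Cn1c(COc2cccc(C(=O)O)c2)nc2ccc(Oc3ccc(F)cn3)cc21` has not yet been measured. It differs from compound 2 in one place: 5-fluoropyridin-2-yl in place of 4-chloropyridin-2-yl on an oxygen on an aromatic ring. Among the measured compounds shown here, no step between measured compounds has been recorded, so there is no measured guide for a change of this kind. A fluorine enters where a chlorine left, and the pyridinyl ring with its single hydrogen-bond acceptor remains. On that basis only a small rise is expected, one that may well stay within the scatter, with an estimated step of a 1.4-fold higher number from compound 2 to compound 3 (0.13 log units; within the scatter). Compound 3 is expected at 15 ug/mL, between 7 ug/mL and 35 ug/mL.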

Compound 3, solubility: 79 ug/mL
Compound 3: the middle estimate sits 5.3-fold (0.72 log units) below what was measured; measured number outside the range, above it.
By their numbers in this assay, from the lowest: compounds 2 and 1 (each within the scatter of the next); then compound 3.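

In this assay, putting 5-fluoropyridin-2-yl in place of 4-chloropyridin-2-yl on an oxygen on an aromatic ring gives a 7.2-fold higher number from compound 2 to compound 3 (0.86 log units; beyond the scatter). The earlier compounds shown here offered no step that differed in one place, and this one shows that the number can move at this position even when the heavy-atom count, the ring and the hydrogen-bond acceptor count stay as they were. Nothing given here accounts for the size of the step.

The step changes both the halogen and where it sits on the pyridinyl ring, so the compounds shown cannot separate these two changes. They also leave open how this position would read with an unsubstituted pyridin-2-yl, a methoxy group or an amine on that ring.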